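Adding Chloro to the Shared Core of Compound 3

The compounds below may be only part of what the source reports. "The series", "measured", "known", "first", "only" and "open" are said of these compounds alone.

Compound 1 `O=S(=O)(Nc1cccc2cc[nH]c12)c1ccc(Cl)cc1` gives 6 ug/mL in a functional assay on P388 cells (Mus musculus) for antiproliferative activity, read by colorimetric assay and MTT assay; on this read-out higher numbers stand for weaker inhibition and lower numbers for stronger inhibition. Compound 2 `O=S(=O)(Nc1cccc2c(Cl)c[nH]c12)c1ccc(Cl)cc1` carries chloro in place of hydrogen on an aromatic carbon and gives 4.3 ug/mL in this assay; the step is a 1.4-fold lower number from compound 1 to compound 2 (0.14 log units; within the scatter). Compound 3 `Nc1ccc(S(=O)(=O)Nc2cccc3cc[nH]c23)cc1` differs from compound 1 by amino in place of chloro on an aromatic carbon. In this assay compound 3 gives 14 ug/mL, the highest number of the three, with a 2.3-fold higher number from compound 1 to compound 3 (0.37 log units; beyond the scatter). Compound 4 `Nc1ccc(S(=O)(=O)Nc2cccc3cc(Cl)[nH]c23)cc1` is not yet measured; it differs from compound 3 by chloro in place of hydrogen on an aromatic carbon. This is the same kind of change as that from compound 1 to compound 2, but not the same: in compound 2 the chloro sits two ring bonds from the ring nitrogen, whereas in compound 4 it sits next to the ring nitrogen. Because the earlier step of a 1.4-fold lower number from compound 1 to compound 2 (0.14 log units; within the scatter) was small, only a small shift is expected here. Compound 4 is expected to give about 11 ug/mL, with a likely range from 5 ug/mL to 25 ug/mL, meaning a 1.3-fold lower number from compound 3 to compound 4 (0.10 log units; within the scatter).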

Compound 4, half-maximal inhibitory concentration: 2.2 ug/mL
Compound 4: middle estimate off by 5.0-fold (0.70 log units), on the high side, and the stated range ends above it.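

In this assay, chloro in place of hydrogen next to the ring nitrogen gives a 6.4-fold lower number from compound 3 to compound 4 (0.80 log units; beyond the scatter). This step does not match the earlier one in size, so the size of the change did not carry over from one core to the other: the same change on two cores in this assay, a 1.4-fold lower number (0.14 log units; within the scatter) from compound 1 to compound 2 and a 6.4-fold lower number (0.80 log units; beyond the scatter) from compound 3 to compound 4, 4.6-fold (0.66 log units) apart, beyond the scatter of two such steps The chloro also stands at a different place in the two steps, so these compounds do not show whether the gap belongs to the core or to the place.

The compounds shown leave open how chloro next to the ring nitrogen behaves on the core of compound 1. They also leave open whether bromo or methyl at that place on the core of compound 3 would give a step of similar size.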